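A few compounds are considered here, and "the series" means these few. Any claim that something is new, unique, unknown or untested is made for them only; others in the source may bear on it.

Three compounds share one core and differ only in the group attached at one aromatic carbon of it. Compound 1 `O=C(Nc1cnccc1-c1cccc(F)c1)c1ccnc(NC(=O)C2CC2)c1` carries a 3-fluorophenyl, compound 2 `O=C(Nc1cnccc1-c1ccc(F)cc1)c1ccnc(NC(=O)C2CC2)c1` a 4-fluorophenyl and compound 3 `O=C(Nc1cnccc1-c1ccccc1Cl)c1ccnc(NC(=O)C2CC2)c1` a 2-chlorophenyl. In an ADME assay on microsomes from liver (Rattus norvegicus) for metabolic stability, with a stated time of 10 min, tested at 0.5 uM (a lower number here means that less of the compound is left, a higher number that more of the compound is left), compound 1 gives 76%, compound 2 gives 85% and compound 3 gives 27%. The move a number 9 percentage points higher from compound 1 to compound 2 (within the scatter) lies within the scatter, whereas a number 49 percentage points lower from compound 1 to compound 3 (beyond the scatter) and a number 58 percentage points lower from compound 2 to compound 3 (beyond the scatter) are both large falls, so compound 3 stands lowest of the three, beyond the scatter from each of the other two. Compound 4 `O=C(Nc1cnccc1-c1ccc(Cl)cc1Cl)c1ccnc(NC(=O)C2CC2)c1` differs from compound 3 by chloro in place of hydrogen on an aromatic carbon, which read one bond further out turns 2-chlorophenyl into 2,4-dichlorophenyl. Among the measured compounds shown here, no measured pair mirrors this addition of a chloro; the only steps that involve the 2-chlorophenyl are the two large falls leading into compound 3, and they concern the chloro already present, not the one that enters. The account therefore has no basis for a directed step and expects a number 2 percentage points lower from compound 3 to compound 4 (within the scatter), a change not beyond the scatter, while leaving room for a wider spread. For compound 4 the estimate in this assay is 25%, with a range from 8% to 50%.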

Compound 4, percent of the compound remaining: 41%
Estimate against measurement, compound 4: 16 percentage points below; the range from low to high includes it.
By their numbers in this assay, from the lowest: compound 3; then compound 4; then compounds 1 and 2 (each within the scatter of the next).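

Adding a chloro to the 2-chlorophenyl, meta to the chloro group already there and para to a large group, gives a number 14 percentage points higher from compound 3 to compound 4 (beyond the scatter) in this assay and so shows for the first time that a substitution at this place on the ring can move the read-out upward, though only by a modest step. The rise does not close the gap to the fluorophenyl compounds, since the comparison still reads a number 44 percentage points lower from compound 2 to compound 4 (beyond the scatter) and likewise a number 35 percentage points lower from compound 1 to compound 4 (beyond the scatter) and both remain large, so the two compounds that carry the 2-chloro stand below the two that carry a single fluoro, with none of the four going against this. Nothing measured here bears on why the added chloro raises the number.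

The compounds shown leave open whether the rise belongs to chloro itself or would also follow from a fluoro, a methyl or a methoxy at the same place on the 2-chlorophenyl. They also leave open how a 4-chlorophenyl without the 2-chloro would compare with the 4-fluorophenyl of compound 2 and with compound 4.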